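Removing the Ring Methyl from the Weakest Analogue

The compounds below may be only part of what the source reports. "The series", "measured", "known", "first", "only" and "open" are said of these compounds alone.

Three compounds share one core and differ only in the ring attached to the double-bonded chain carbon. Compound 1 `COc1cccc(/C=C/C(=O)NNC(=O)c2ccc3c(c2)OCCO3)c1` gives 170 nM in a functional assay on cells (Cancer cell lines, Homo sapiens) for inhibition, read by MTT assay, with a stated time of 48 h; a lower number here means a stronger inhibitor, a higher number a weaker inhibitor. Compound 2 `Cc1ccc(/C=C/C(=O)NNC(=O)c2ccc3c(c2)OCCO3)cc1` gives 1050 nM, and compound 3 `Cc1ccccc1/C=C/C(=O)NNC(=O)c1ccc2c(c1)OCCO2` gives 7710 nM. Compound 3 thus carries the highest number of the three: the steps of a 7.3-fold higher number from compound 2 to compound 3 (0.87 log units; beyond the scatter) and a 45-fold higher number from compound 1 to compound 3 (1.66 log units; beyond the scatter) both place it beyond the scatter from the others, and a 6.2-fold higher number from compound 1 to compound 2 (0.79 log units; beyond the scatter) shows that compound 2 in turn trails compound 1.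

Compound 4 `O=C(/C=C/c1ccccc1)NNC(=O)c1ccc2c(c1)OCCO2` differs from compound 3 by hydrogen in place of methyl on an aromatic carbon. Within the data shown here, no measured step removes a methyl outright; the closest guidance is that changing where the methyl sits, as in a 7.3-fold higher number from compound 2 to compound 3 (0.87 log units; beyond the scatter), cost a modest amount, and that every change on this ring so far has moved the number beyond the scatter. Taking the methyl away is therefore expected to lower the number, and compound 4 is estimated at 1500 nM (range 500 nM to 5000 nM), an expected step of a 5.1-fold lower number from compound 3 to compound 4 (0.71 log units; beyond the scatter) in this assay.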

Compound 4, half-maximal inhibitory concentration: 550 nM
Compound 4: the middle estimate sits 2.7-fold (0.44 log units) above what was measured; the range from low to high includes it.
By their numbers in this assay, from the lowest: compound 1; then compounds 4 and 2 (each within the scatter of the next); then compound 3.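

Taking the methyl off the 2-methylphenyl ring gives a 14-fold lower number from compound 3 to compound 4 (1.15 log units; beyond the scatter) in this assay, which shows that on this ring the methyl of compound 3 comes with a large rise in the number and that plain phenyl does far better. The same removal from the 4-methylphenyl ring gives a 1.9-fold lower number from compound 2 to compound 4 (0.28 log units; within the scatter), within the scatter, so the methyl's cost depends on where it sits, while a 3.2-fold higher number from compound 1 to compound 4 (0.51 log units; beyond the scatter) shows that phenyl still falls short of the 3-methoxyphenyl ring of compound 1. No measured evidence accompanies these results to explain the differences.

From the compounds shown here alone, it remains open whether the lower number of compound 1 belongs to the methoxy group or to its place on the ring, a question that 3-methylphenyl and 4-methoxyphenyl rings could separate. Going by these compounds, how a ring carrying an amine, as in 3-aminophenyl, would compare also remains open.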